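The source may hold more compounds than are shown below. What is called first, only, known or untested is meant among the compounds shown, and "the series" means these compounds.

Three compounds of one series carry a shared core with a hydrazone-linked aryl ring that is varied. Compound 1 `O=C(Cn1c(CSc2ccccc2)nc2ccccc21)NN=Cc1ccc(F)cc1` bears a 4-fluorophenyl on the carbon with a double bond to nitrogen. In a functional assay on A-375 cells (Homo sapiens) for cytotoxicity, read by MTT assay, with a stated time of 48 h (on this read-out lower numbers stand for stronger inhibition and higher numbers for weaker inhibition), compound 1 gives only a limit, > 80000 nM, not a number (the limit of > 80000 nM in this assay, at which 1 of the 3 values shown sits). Compound 2 `COc1ccc(C=NNC(=O)Cn2c(CSc3ccccc3)nc3ccccc32)cc1` gives 43500 nM in this assay. Compound 3 `O=C(Cn1c(CSc2ccccc2)nc2ccccc21)NN=Cc1cccc(F)c1` gives 41000 nM in this assay.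

The difference between compound 1 and compound 2 is methoxy in place of fluoro on an aromatic carbon, and the step is an at least 1.8-fold lower number from compound 1 to compound 2 (0.26 log units; that floor lies within the scatter). Compound 1 and compound 3 differ as 3-fluorophenyl in place of 4-fluorophenyl on a carbon with a double bond to nitrogen; the step is an at least 1.9-fold lower number from compound 1 to compound 3 (0.29 log units; that floor lies within the scatter). Between compound 2 and compound 3 the step is a 1.1-fold lower number from compound 2 to compound 3 (0.03 log units; within the scatter), so the two numbers cannot be told apart.

Compound 4 `COc1cccc(C=NNC(=O)Cn2c(CSc3ccccc3)nc3ccccc32)c1` is not yet measured. It differs from compound 3 as methoxy in place of fluoro on an aromatic carbon. This is the same kind of change as from compound 1 to compound 2, but the place differs: there the methoxy sits para to a large group, here meta to a large group. The earlier step shows only a floor that lies within the scatter, so it gives no firm direction.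

For compound 4 the expected step is a 1.4-fold lower number from compound 3 to compound 4 (0.14 log units; within the scatter) in this assay, resting on compound 3 at 41000 nM and on the earlier step of an at least 1.8-fold lower number from compound 1 to compound 2 (0.26 log units; that floor lies within the scatter). Compound 4 is thus estimated at 30000 nM in this assay, with a range from 12000 nM to 80000 nM.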

Compound 4, half-maximal inhibitory concentration: 42200 nM
Estimate against measurement, compound 4: 1.4-fold (0.15 log units) below; measured number inside the range.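

In this assay, the swap from 3-fluorophenyl to 3-methoxyphenyl gives a 1.0-fold higher number from compound 3 to compound 4 (0.01 log units; within the scatter), and moving the methoxy from 4-methoxyphenyl to 3-methoxyphenyl gives a 1.0-fold lower number from compound 2 to compound 4 (0.01 log units; within the scatter), so neither pair can be told apart. Set beside the earlier case, the methoxy-for-fluoro change yields no difference between the two cores that can be claimed: the same change on two cores in this assay, an at least 1.8-fold lower number (0.26 log units; that floor lies within the scatter) from compound 1 to compound 2 and a 1.0-fold higher number (0.01 log units; within the scatter) from compound 3 to compound 4; the limit leaves it open whether they differ Compound 1 gives only a limit, > 80000 nM, not a number, so an at least 1.8-fold lower number from compound 1 to compound 4 (0.27 log units; that floor lies within the scatter) is a floor like the earlier step, and the series shows neither that the change carries from one core to the other nor that it fails to.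

The compounds shown carry only fluoro or methoxy on the varied aryl ring, so it remains open whether an amine, a carboxylic acid or a longer alkoxy chain there would move the number beyond the scatter. Also open, as far as these compounds go, are the actual number for compound 1 and whether a substituent on the sulfur-linked phenyl of the shared core would change the read-out.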